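This account rests on a few compounds, and the source may have more. Where it says the series, first, only, none or still open, it means among the compounds named here.

In a functional assay on A549 cells (Homo sapiens) for antiproliferative activity, read by sulforhodamine B assay, with a stated time of 48 h (on this read-out higher numbers stand for weaker inhibition and lower numbers for stronger inhibition), compound 1 (`COc1cccc(/C=C/C(=O)/C=C(O)/C=C/c2cccc(OC)c2OC)c1OC`) gives 11500 nM and compound 2 (`COc1ccc(C=C(C(=O)/C=C/c2cccc(OC)c2OC)C(=O)/C=C/c2cccc(OC)c2OC)cc1OC`) gives 170 nM as its value. Compound 3 (`COc1cccc(C=C(C(=O)/C=C/c2cccc(OC)c2OC)C(=O)/C=C/c2cccc(OC)c2OC)c1OC`) gives 320 nM as its value, far under that of compound 1 yet within the scatter of compound 2. Compound 4 (`COc1ccc(C=C(C(=O)/C=C/c2cccc(OC)c2OC)C(=O)/C=C/c2cccc(OC)c2OC)cc1O`) has 3-hydroxy-4-methoxyphenyl in place of 2,3-dimethoxyphenyl on a double-bonded chain carbon bound to a double-bonded chain carbon. Among the measured compounds shown here, the one measured swap at this place (a 1.9-fold higher number from compound 2 to compound 3 (0.27 log units; within the scatter)) stayed small, so no step beyond the scatter is expected here, although no measured compound carries this hydroxy group. The estimated change (a 1.2-fold lower number from compound 3 to compound 4 (0.09 log units; within the scatter)) therefore stays within the scatter. Compound 4 is expected at 260 nM (estimated range 90 nM to 750 nM).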

Compound 4, half-maximal inhibitory concentration: 270 nM
The estimate for compound 4 lay 1.0-fold (0.02 log units) below the measured number; measured number inside the range.
By their numbers in this assay, from the lowest: compounds 2, 4 and 3 (each within the scatter of the next); then compound 1.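

Replacing the 2,3-dimethoxyphenyl group with 3-hydroxy-4-methoxyphenyl at this place gives only a small step (a 1.2-fold lower number from compound 3 to compound 4 (0.07 log units; within the scatter)), and so does hydrogen in place of methyl on an oxygen on an aromatic ring (a 1.6-fold higher number from compound 2 to compound 4 (0.20 log units; within the scatter)). Both steps lie within the scatter, so this place has now accepted a ring with a hydrogen-bond donor without a clear change in the number. Nothing here explains why these changes matter so little. Still open, from the compounds shown here alone, is whether an amine or a carboxylic acid on this ring would also leave the number unchanged.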